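Methyl added on the chain: from hydrazone to reduced analogue

The source may report more compounds than this note shows. Statements on the series, on what has been measured and on what is new or still open speak of the compounds shown alone.

Of the compounds shown here, three have been measured so far in a functional assay on B16 cells (Mus musculus) for inhibition, with a stated time of 3 days; a higher number here means a weaker inhibitor, a lower number a stronger inhibitor. Compound 1, with structure `C/C(=N\NC(N)=S)c1ccc(C)cc1`, gives 840 nM in this assay. Compound 2, with structure `CC/C(=N\NC(N)=S)c1ccc(C)cc1`, carries the change methyl in place of hydrogen on a saturated chain carbon bound to a carbon with a double bond to nitrogen relative to compound 1, and in this assay compound 2 gives 2600 nM. That single change produced a 3.1-fold higher number from compound 1 to compound 2 (0.49 log units; beyond the scatter). Compound 3, with structure `Cc1ccc(C(C)NNC(N)=S)cc1`, gives 8100 nM in this assay, the highest of the three numbers; the difference between the core of compound 3 and the core of compound 1 is not broken down here.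

Compound 4, with structure `CCC(NNC(N)=S)c1ccc(C)cc1`, has not yet been measured. It differs from compound 3 by methyl in place of hydrogen on a saturated chain carbon, two bonds along the chain from an amine nitrogen and an aromatic carbon. Among the measured compounds shown here, this is the same kind of change as the one from compound 1 to compound 2, but its surroundings are not identical: in compound 2 the new methyl sits on a saturated chain carbon bound to a carbon with a double bond to nitrogen, whereas in compound 4 it sits on a saturated chain carbon, two bonds along the chain from an amine nitrogen and an aromatic carbon.

The step from compound 3 to compound 4 in this assay is expected to be a 2.7-fold higher number from compound 3 to compound 4 (0.43 log units; beyond the scatter), because the same kind of change gave a 3.1-fold higher number from compound 1 to compound 2 (0.49 log units; beyond the scatter). On that basis compound 4 is estimated at 22000 nM, with a range expected from 7000 nM to 70000 nM.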

Compound 4, half-maximal inhibitory concentration: 3900 nM
For compound 4 the middle estimate is 5.6-fold (0.75 log units) above the measured one, outside the stated range (below it).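

The methyl group did not do the same thing on both cores. In this assay, adding it to the reduced core of compound 3 gives a 2.1-fold lower number from compound 3 to compound 4 (0.32 log units; beyond the scatter), so the compound became a stronger inhibitor, whereas the same addition to the hydrazone core made the compound weaker, and the gap between the two results is real rather than noise in the measurements: the same change on two cores in this assay, a 3.1-fold higher number (0.49 log units; beyond the scatter) from compound 1 to compound 2 and a 2.1-fold lower number (0.32 log units; beyond the scatter) from compound 3 to compound 4, 6.4-fold (0.81 log units) apart, beyond the scatter of two such steps. Among the compounds shown here, this shows that, in this series, the effect of the change cannot simply be carried from one core to the other, but with only two pairs it gives no general rule for other cores or other groups, and it does not explain why the direction reverses.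

As far as these compounds go, it remains open how the trend would continue if the chain grew further, from ethyl to propyl, on each of the two cores, and whether the two cores would keep moving in opposite directions. A branched isopropyl group or a small cyclopropyl ring in the same place would likewise test whether the reversal is particular to the step from methyl to ethyl.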